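Swapping the aryl group on the ring nitrogen

This account rests on a few compounds, and the source may have more. Where it says the series, first, only, none or still open, it means among the compounds named here.

Of the compounds shown here, two built on one shared core have been measured. Compound 1 `Nc1scc(CN2CCN(c3ccc(Cl)c(C(F)(F)F)c3)CC2)c1C(=O)c1ccc(Cl)cc1` gives -60% in a functional assay on CHO cells with adenosine receptor A1 (Homo sapiens) as the target, read by cAMP accumulation and immunoassay, with a stated time of 6 min, tested at 10 uM; on this read-out higher numbers stand for a weaker effect at the one concentration tested and lower numbers for a stronger effect. Compound 2 `Nc1scc(CN2CCN(c3cccc4ccccc34)CC2)c1C(=O)c1ccc(Cl)cc1` gives -21% in this assay, the higher of the two numbers and so the weaker effect at the single concentration tested. Among the measured compounds shown here, the one measured step, a number 39 percentage points higher from compound 1 to compound 2 (beyond the scatter), came with naphthalen-1-yl in place of 4-chloro-3-(trifluoromethyl)phenyl on an amine nitrogen in a ring. Compound 3 `Nc1scc(CN2CCN(c3cccc(F)c3)CC2)c1C(=O)c1ccc(Cl)cc1` has not yet been measured; it differs from compound 2 by 3-fluorophenyl in place of naphthalen-1-yl on an amine nitrogen in a ring. For the measured compounds named here, the only step that bears on this change, a number 39 percentage points higher from compound 1 to compound 2 (beyond the scatter), shows that exchanging the group on this ring nitrogen can move the read-out by a large amount, but it gives no indication of which way a 3-fluorophenyl will move it. Compound 3 is therefore expected to land near -35%, within a wide range from -70% to 5%. This estimate corresponds to an expected step of a number 14 percentage points lower from compound 2 to compound 3 (beyond the scatter), whose direction remains uncertain.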

Compound 3, a percentage reported as activity, at one concentration (the size of the read-out at that concentration, not a potency): -82%
The estimate for compound 3 lay 47 percentage points above the measured number; the measured number lies below the stated range.
By their numbers in this assay, from the lowest: compound 3; then compound 1; then compound 2.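

In this assay the new results give this position a direction as well as a size: the number is a number 61 percentage points lower from compound 2 to compound 3 (beyond the scatter) and also a number 22 percentage points lower from compound 1 to compound 3 (beyond the scatter) after the same kind of exchange. Compound 3 therefore has the strongest effect of the three at the single concentration tested, and the two substituted phenyl groups, in compound 1 and compound 3, both give lower numbers than naphthalen-1-yl in compound 2. Nothing available explains why these groups differ in this way.

As far as these compounds go, it remains open whether the fluorine matters, which a plain phenyl group on the same ring nitrogen could test, and whether a 4-fluorophenyl group would act like 3-fluorophenyl. These numbers also describe a stronger or weaker effect of the three compounds only at the single concentration tested and at no other.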